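Removing bromo from compound 1

The compounds below may be only part of what the source reports. "The series", "measured", "known", "first", "only" and "open" are said of these compounds alone.

Measured in a functional assay on HepG2 cells (Homo sapiens) for antiproliferative activity, read by MTT assay, with a stated time of 48 h; on this read-out higher numbers stand for weaker inhibition and lower numbers for stronger inhibition:
- compound 1 `O=C(/C=C/c1ccccc1Br)c1nc2ccccc2[nH]1`: 29200 nM
- compound 2 `COc1cccc(/C=C/C(O)c2nc3ccccc3[nH]2)c1`: > 100000 nM (a limit)
- compound 3 `O=C(/C=C/c1ccccn1)c1nc2ccccc2o1`: > 100000 nM (a limit)

Compound 1 is the only one of the three with an actual number, 29200 nM. For compound 2 and compound 3 the reading is the limit of > 100000 nM in this assay, at which 2 of the 3 values shown sit.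

Compound 4 `O=C(/C=C/c1ccccc1)c1nc2ccccc2[nH]1` is still unmeasured. Its difference from compound 1 is hydrogen in place of bromo on an aromatic carbon. Among the measured compounds shown here, no measured pair in the set isolates this change, so the expectation is loose. A modest move towards weaker inhibition is expected in this assay, and possibly none beyond the scatter. The expected 1.4-fold higher number from compound 1 to compound 4 (0.14 log units; within the scatter) is therefore small. For compound 4 the estimated value is 40000 nM, with an expected range of 13000 nM to 100000 nM.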

Compound 4, half-maximal inhibitory concentration: 6300 nM
The estimate for compound 4 lay 6.3-fold (0.80 log units) above the measured number, and the stated range ends above it.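

In this assay, hydrogen in place of bromo gives a 4.6-fold lower number from compound 1 to compound 4 (0.67 log units; beyond the scatter), so the bromo group on this aromatic carbon, ortho to a large group, is not needed for antiproliferative activity on these cells. Among the compounds shown here, this is the first single-place comparison, and at this position it favours hydrogen over bromo. Nothing measured here accounts for the step. Still open, going by these compounds, is whether fluoro or an amine at this position would read closer to hydrogen or to bromo. Also open, on these data alone, is whether bromo elsewhere on this ring would carry the same cost.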